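A few compounds are considered here, and "the series" means these few. Any claim that something is new, unique, unknown or untested is made for them only; others in the source may bear on it.

Compound 1 `COc1cc(O)c(CC=C(C)C)c(O)c1C(=O)/C=C/c1ccc(O)c(O)c1`: 15200 nM
Compound 2 `COc1cc(OC)c(C(=O)/C=C/c2ccc(O)cc2)c(OC)c1`: 37000 nM
Compound 3 `COc1cc(OC)c(C(=O)/C=C/c2ccc(O)c(O)c2)c(OC)c1`: 27500 nM

All three compounds were tested in a functional assay on HepG2 cells (Homo sapiens) for inhibition, read by MTT assay, with a stated time of 72 h; a lower number here means a stronger inhibitor, a higher number a weaker inhibitor. Here compound 2, at 37000 nM, lies within the scatter of compound 3, at 27500 nM, while compound 1 gives a lower number, 15200 nM.

Compound 4 `COc1cc(OC)c(C(=O)/C=C/c2ccc(C(F)(F)F)cc2)c(OC)c1` has not yet been measured. It departs from compound 2 in one place: trifluoromethyl in place of hydroxy on an aromatic carbon. This is trifluoromethyl in place of hydroxy on an aromatic carbon, para to a large group.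

Among the measured compounds shown here, only one measured step bears on this change, and only indirectly: a 1.3-fold lower number from compound 2 to compound 3 (0.13 log units; within the scatter), which is hydroxy in place of hydrogen on an aromatic carbon. For the measured compounds named here, no measured pair shows trifluoromethyl entering, and compound 1 differs from compound 2 in more than one place, so it offers no clean comparison. Going by the values given here, since the one step available, a 1.3-fold lower number from compound 2 to compound 3 (0.13 log units; within the scatter), stays within the scatter, no shift beyond the scatter is expected in this assay, and no direction is favoured. The expected step is a 1.1-fold lower number from compound 2 to compound 4 (0.02 log units; within the scatter). The range must stay wide, as the entering group has not been tested in this series. For compound 4 the estimated value is 35000 nM, with an expected range from 12000 nM to 90000 nM.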

Compound 4, half-maximal inhibitory concentration: 9700 nM
Compound 4: middle estimate off by 3.6-fold (0.56 log units), on the high side, and the stated range ends above it.
By their numbers in this assay, from the lowest: compounds 4, 1, 3 and 2 (each within the scatter of the next, the first and the last beyond it).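

Among the compounds shown here, the earlier compounds offered only one step on this six-membered aromatic ring, and it stayed within the scatter (a 1.3-fold lower number from compound 2 to compound 3 (0.13 log units; within the scatter)), so they gave no sign that a change on this ring could shift the number in this assay. Trifluoromethyl in place of hydroxy on the aromatic carbon para to a large group does shift it beyond the scatter (a 3.8-fold lower number from compound 2 to compound 4 (0.58 log units; beyond the scatter)), so this place responds to a change of group, although the step is modest. It also shows that a hydroxy at this place is not needed for inhibition in this assay, as compound 4 has no hydrogen-bond donor in the entering group and still gives the lower number. No measurement of any property accompanies this step, so the data offer no reason for it.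

The compounds shown leave open whether the shift comes from trifluoromethyl entering or from hydroxy leaving, as none of them has a plain hydrogen at this place while the rest of compound 2 stays the same. They also leave open whether a nitrile, an amine or a carboxylic acid here would move the number the same way, and whether trifluoromethyl would do so on the core of compound 1.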